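The source may report more compounds than this note shows. Statements on the series, on what has been measured and on what is new or still open speak of the compounds shown alone.

Measured in a physicochemical assay for solubility, at pH 7; a higher number here means a more soluble compound, a lower number a less soluble compound:
Compound 1 `CN1CCC(C(=O)N2Cc3c(NC(=O)C4CC4)n[nH]c3C2(C)C)CC1`: > 225000 nM
Compound 2 `CN1CCC(C(=O)N2Cc3c(NC(=O)c4cccs4)n[nH]c3C2(C)C)CC1`: 155000 nM

The reading for compound 1 is a limit of this assay. Among the compounds with values here, compound 2, at 155000 nM, therefore holds the only actual number so far. The next structure is compound 3 `CN1CCC(C(=O)N2Cc3c(NC(=O)c4ccncc4)n[nH]c3C2(C)C)CC1`, which has pyridin-4-yl in place of thiophen-2-yl on a carbonyl carbon.

Within the data shown here, only one measured step bears on this change, at the same kind of carbonyl carbon: an at least 1.4-fold lower number from compound 1 to compound 2 (0.16 log units; that floor lies within the scatter). That step involves thiophen-2-yl but not pyridin-4-yl, so it offers only weak guidance. On that small step, no change beyond the scatter is expected in this assay, and the estimated step is a 1.2-fold higher number from compound 2 to compound 3 (0.09 log units; within the scatter). For compound 3 the expected value is 190000 nM, with an estimated range from 100000 nM to 225000 nM.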

Compound 3, solubility: > 225000 nM
Compound 3 gave a limit, no number; the forecaster's own chance of this, stated with the estimate: 40%; middle value at least 1.1-fold (0.07 log units) from the limit.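

In this assay compound 3 gives > 225000 nM, which is a limit, so pyridin-4-yl joins cyclopropyl as a group on this carbonyl carbon that gives a limit and no number. Going from thiophen-2-yl to pyridin-4-yl gives an at least 1.4-fold higher number from compound 2 to compound 3 (0.16 log units; that floor lies within the scatter), so the single-change steps on both sides of compound 2 now end in a limit, and neither floor clears the scatter. The step between the two compounds that read as limits cannot be read, and the series offers little room for sizing changes at this position: the limit of > 225000 nM in this assay, at which 2 of the 3 values shown sit.

As far as these compounds go, the actual values of compound 1 and compound 3 remain open, and so does any firm order among the three groups. Also open, from the compounds shown here alone, is whether an amine, a carboxylic acid or a longer chain on this carbonyl carbon would give a number in this assay.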